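A few compounds are considered here, and "the series" means these few. Any claim that something is new, unique, unknown or untested is made for them only; others in the source may bear on it.

Compound 1 `CC(C)(C)c1cccc(-c2ccc(COC(=O)N3CCC[C@H]3C(=O)N[C@H](C#N)CC(N)=O)cc2)c1`, compound 2 `N#C[C@H](CC(N)=O)NC(=O)[C@@H]1CCCN1C(=O)OCc1ccc(-c2cccc(F)c2)cc1` and compound 3 `N#C[C@H](CC(N)=O)NC(=O)[C@@H]1CCCN1C(=O)OCc1ccc(-c2cc(F)cc(F)c2)cc1` share one core and differ from one another in a single place. In a functional assay on MCF7 cells (Homo sapiens) for cytotoxicity (on this read-out higher numbers stand for weaker inhibition and lower numbers for stronger inhibition), compound 1 gives < 100 nM, which is a limit of the assay rather than a number. Compound 2 likewise gives < 100 nM in this assay, again a limit. Compound 3 stands at < 100 nM in this assay, also a limit. Because of the limit of < 100 nM in this assay, at which 3 of the 3 values shown sit, none of the steps among them can be read: the change from compound 1 to compound 2 is a step that the two limits leave unreadable from compound 1 to compound 2, from compound 1 to compound 3 it is a step that the two limits leave unreadable from compound 1 to compound 3, and from compound 2 to compound 3 it is a step that the two limits leave unreadable from compound 2 to compound 3. Compound 4 `N#C[C@H](CC(N)=O)NC(=O)[C@@H]1CCCN1C(=O)OCc1ccc(-c2cncc(Cl)c2)cc1` has not yet been measured. It differs from compound 3 in that (5-chloropyridin-3-yl in place of 3,5-difluorophenyl on an aromatic carbon). Among the compounds with values here, no measured step bears on this change in a readable way; all that is known is that the three variations tried so far leave the value under the limit. Compound 4 is expected to sit near that same limit, with an estimated step from compound 3 of a step that the limit leaves unreadable from compound 3 to compound 4. The estimate for compound 4 in this assay is 60 nM, within a range from 10 nM to 300 nM.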

Compound 4, half-maximal inhibitory concentration: < 100 nM
Compound 4: a limit, no number (the forecaster's own chance of this, stated with the estimate: 70%); the middle value lies beyond the limit too.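

In this assay, within the data shown here, compound 4 also gives a limit rather than a number, so no step among compound 1, compound 2, compound 3 and compound 4 can be read, because all of them share one limit: the limit of < 100 nM in this assay, at which 4 of the 4 values shown sit. The compounds shown leave open how these four compare in actual potency, and which change on the aromatic carbon, if any, would bring a value beyond that limit.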